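The compounds below may be only part of what the source reports. "The series", "measured", "known", "first", "only" and "open" are said of these compounds alone.

Measured compounds in an ADME assay on L6 cells (Rattus norvegicus) for cytotoxicity; on this read-out higher numbers stand for weaker inhibition and lower numbers for stronger inhibition:

compound 1, `O=C(Nc1c(O)cccc1-c1nc2c(C(=O)O)cccc2o1)c1cccnc1`, gives 240000 nM
compound 2, `O=C(Nc1c(O)cccc1-c1nc2c(C(=O)O)cccc2o1)c1ccc(F)c(F)c1F`, gives 210000 nM
compound 3, `O=C(Nc1c(O)cccc1-c1nc2c(C(=O)O)cccc2o1)c1cc(-c2ccccc2)on1`, gives 141000 nM

Compound 3 holds the lowest of the three numbers, but the step of a 1.5-fold lower number from compound 2 to compound 3 (0.17 log units; within the scatter) and the step of a 1.7-fold lower number from compound 1 to compound 3 (0.23 log units; within the scatter) are both within the scatter, so the three compounds are not separated by this assay. The step of a 1.1-fold lower number from compound 1 to compound 2 (0.06 log units; within the scatter) is within the scatter as well.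

Compound 4, `O=C(Nc1c(O)cccc1-c1nc2c(C(=O)O)cccc2o1)c1ncccc1O`, is not yet measured. It differs from compound 3 in one place: 3-hydroxypyridin-2-yl in place of 5-phenyl-1,2-oxazol-3-yl on a carbonyl carbon.

All three measured steps bear on this change, since each of them exchanges the group on the same carbonyl carbon, attached to the amide-type nitrogen of the shared core. None of them moved the number beyond the scatter. The exchange to the 3-hydroxypyridin-2-yl group is of the same kind, and nothing in the data suggests that this position sets the number in this assay. The expected step of a 1.3-fold higher number from compound 3 to compound 4 (0.11 log units; within the scatter) is therefore none beyond the scatter, with a middle value near the three measured numbers. Compound 4 is estimated at 180000 nM, in the range from 80000 nM to 400000 nM.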

Compound 4, half-maximal inhibitory concentration: 14200 nM
Compound 4: the middle estimate sits 13-fold (1.10 log units) above what was measured; the whole stated range lies above it.
By their numbers in this assay, from the lowest: compound 4; then compounds 3, 2 and 1 (each within the scatter of the next).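

In this assay the group on the carbonyl carbon turns out to matter: the step of a 9.9-fold lower number from compound 3 to compound 4 (1.00 log units; beyond the scatter), the step of a 15-fold lower number from compound 2 to compound 4 (1.17 log units; beyond the scatter) and the step of a 17-fold lower number from compound 1 to compound 4 (1.23 log units; beyond the scatter) all lie beyond the scatter, while exchanges among the three earlier groups stayed within it. The earlier compounds therefore showed only that these three groups are not told apart by this read-out, not that the position is without influence, and 3-hydroxypyridin-2-yl is the one group shown that separates from all the others. Among the four compounds, it is also the only group on this carbonyl carbon with a hydrogen-bond donor in the count, but nothing available explains the shift, and this remains a correlation from a single compound.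

The compounds shown leave open whether the hydroxy group of 3-hydroxypyridin-2-yl is needed for the lower number, which a methoxy group or an amine in its place would test. They also leave open whether the step persists when the carboxylic acid of the shared core is replaced by a methyl ester.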